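Hydroxy for ethyl on two purine-based amide series

The source may hold more compounds than are shown below. What is called first, only, known or untested is meant among the compounds shown, and "the series" means these compounds.

Compound 1 `CC[C@H](C)[C@H](NC(=O)CN(c1nc(Cl)nc2[nH]cnc12)C1CC1)C(=O)O` and compound 3 `C[C@@H](O)[C@H](NC(=O)CN(c1nc(Cl)nc2[nH]cnc12)C1CC1)C(=O)O` share one core; compound 2 `CC[C@H](C)[C@H](NC(=O)CN(c1ncnc2c1ncn2C1CCCCO1)C1CC1)C(=O)OCc1ccccc1` and compound 4 `C[C@@H](O)[C@H](NC(=O)CN(c1ncnc2c1ncn2C1CCCCO1)C1CC1)C(=O)OCc1ccccc1` share another, and the difference between the two cores is not broken down here. In a functional assay on the whole organism (Tail, strain ICR) with Mus musculus as the target, in the tail flick test, with a stated time of 120 min, at a dose of 25 umol/kg by the oral route (a higher number here means a stronger effect of the compound at the dose given, a lower number a weaker effect), compound 1 gives 21.4%, compound 3 gives 37.6%, and compound 2 gives 20.4%. The change hydroxy in place of ethyl on a saturated chain carbon bound to two saturated chain carbons made a step of a number 16.2 percentage points higher from compound 1 to compound 3 (beyond the scatter). The same change, (hydroxy in place of ethyl on a saturated chain carbon bound to two saturated chain carbons), links compound 2 to compound 4, which is not yet measured in this assay. Because the earlier step of a number 16.2 percentage points higher from compound 1 to compound 3 (beyond the scatter) was modest and the core differs, a somewhat smaller step is expected here, a number 11.6 percentage points higher from compound 2 to compound 4 (beyond the scatter). Compound 4 is therefore estimated at 32%, with a likely range from 18% to 48%.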

Compound 4, a percentage reported as activity, at one dose (the size of the read-out at that dose, not a potency): 10.9%
Compound 4: the middle estimate sits 21.1 percentage points above what was measured, outside the stated range (below it).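

In this assay hydroxy in place of ethyl on a saturated chain carbon bound to two saturated chain carbons gives a number 9.5 percentage points lower from compound 2 to compound 4 (within the scatter) and so leaves no clear change on this core. The gain seen on the core of compound 1 therefore did not carry over, although these two pairs cannot show which difference between the cores matters, or why. The result of this change depends on the core in the two cases shown: the same change on two cores in this assay, a number 16.2 percentage points higher (beyond the scatter) from compound 1 to compound 3 and a number 9.5 percentage points lower (within the scatter) from compound 2 to compound 4, 25.7 percentage points apart, beyond the scatter of two such steps

The compounds shown leave open how an amine or a longer chain in the same place would behave on either core. They also leave open whether a third core would follow either pair.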